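A few compounds are considered here, and "the series" means these few. Any claim that something is new, unique, unknown or untested is made for them only; others in the source may bear on it.

Compound 2, `CCn1nnc(-c2sc(-c3ccccc3O)nc2O)n1`: 24 nM
Compound 1, `CCNC(=O)c1sc(-c2ccccc2)nc1O`: > 100000 nM
Compound 3, `O=C(O)c1sc(-c2ccccc2)nc1O`: > 100000 nM

Of the compounds shown here, three have been measured in an assay on HEK293 cells for inhibition of transient receptor potential cation channel subfamily M member 8 (Homo sapiens), read by FLIPR, with stated times of 5 min and 3 min; a higher number here means a weaker inhibitor, a lower number a stronger inhibitor. Among the measured compounds shown here, compound 2 gives 24 nM, the only number among the three. For compound 1 the assay reports only a limit, > 100000 nM. For compound 3 the assay likewise reports only a limit, > 100000 nM. For the measured compounds named here, both of these sit at the limit of > 100000 nM in this assay, at which 2 of the 3 values shown sit, so the one step between measured compounds that differ in a single place, a step that the two limits leave unreadable from compound 1 to compound 3, cannot be read. Compound 2 differs from compound 1 and from compound 3 in two places each, so their values show nothing about either change taken alone.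

Compound 4, `CCn1nnc(-c2sc(-c3ccccc3C)nc2O)n1`, has not yet been measured in this assay. It differs from compound 2 in one place: methyl in place of hydroxy on an aromatic carbon. Going by the values given here, no measured step bears on this change; the only step in hand, from compound 1 to compound 3, touches a different place and is unreadable in any case. The expectation therefore rests on compound 2 alone, with a broad range. Taking the loss of the hydroxy as more likely to cost than to gain, the step from compound 2 to compound 4 is expected to be a 13-fold higher number from compound 2 to compound 4 (1.10 log units; beyond the scatter) toward weaker inhibition. Compound 4 is thus estimated at 300 nM, between 50 nM and 3000 nM.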

Compound 4, half-maximal inhibitory concentration: 60 nM
Compound 4: the middle estimate sits 5.0-fold (0.70 log units) above what was measured; low and high end bracket the measured number.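

In this assay, among the compounds shown here, methyl in place of hydroxy, on an aromatic carbon ortho to a large group, gives a 2.5-fold higher number from compound 2 to compound 4 (0.40 log units; beyond the scatter), the first step that can be read as a size. The hydroxy is therefore not required for inhibition at this position: compound 4, whose methyl has 0 hydrogen-bond donors and 0 hydrogen-bond acceptors, still gives 60 nM, so the change costs only a modest part of the activity of compound 2. Nothing measured here explains why the step has this size.

The compounds shown leave open how other groups at this same place, such as a methoxy, a fluorine or an amine, would compare with the hydroxy of compound 2 and the methyl of compound 4. They also leave open what the ethyl group contributes, since a longer chain or a plain methyl in its place would be needed to show this, and whether the effect of the methyl holds when another part of the molecule changes.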